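The compounds below may be only part of what the source reports. "The series", "measured", "known", "first", "only" and "open" are said of these compounds alone.

Measured so far:
compound 1, `CN(C)C(=O)c1cc2cnc(Nc3ccc(S(=O)(=O)NCCCCN=C=S)cc3)nc2n1C1CCCC1`, gives 29.9% in a functional assay on NCI-H1299 cells (Homo sapiens) for inhibition, read by CCK-8 assay, with a stated time of 72 h, tested at 1 uM; a higher number here means a stronger effect of the compound at the concentration tested, a lower number a weaker effect.
compound 2, `CN(C)C(=O)c1cc2cnc(Nc3ccc(NC(=O)CCCCN=C=S)cc3)nc2n1C1CCCC1`, gives 58.6% in this assay.

Going by the values given here, on these two numbers compound 2 stands highest; its only neighbour is compound 1, and the single measured step between them, a number 28.7 percentage points higher from compound 1 to compound 2 (beyond the scatter), lies beyond the scatter. That step exchanges the group on the aromatic carbon and says nothing about the chain that carries the terminal group.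

Compound 3, `CN(C)C(=O)c1cc2cnc(Nc3ccc(NC(=O)CCCCCN=C=S)cc3)nc2n1C1CCCC1`, is not yet measured. It differs from compound 2 by a group of 4 heavy atoms (2 carbon, 1 nitrogen, 1 sulfur; no ring) in place of a group of 3 heavy atoms (1 carbon, 1 nitrogen, 1 sulfur; no ring), on a saturated chain carbon, four bonds along the chain from a carbonyl carbon, a change confined to the saturated chain. Among the compounds with values here, no measured step bears on a lengthened chain of this kind, so there is no basis for predicting a shift in either direction; the step from compound 1 to compound 2 is of a different kind and cannot be carried over. The working expectation is therefore a step within the scatter, a number 1.6 percentage points lower from compound 2 to compound 3 (within the scatter), with the uncertainty widened for lack of any comparable precedent.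

Compound 3 is estimated at 57% in this assay, expected range 35% to 78%.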

Compound 3, a percentage reported as inhibition, at one concentration (the size of the read-out at that concentration, not a potency): 34.3%
Estimate against measurement, compound 3: 22.7 percentage points above; measured number below the stated range.
By their numbers in this assay, from the lowest: compounds 1 and 3 (each within the scatter of the next); then compound 2.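

Chain length at this place matters in this assay: on a saturated chain carbon, four bonds along the chain from a carbonyl carbon, the group of 4 heavy atoms in place of the group of 3 heavy atoms gives a number 24.3 percentage points lower from compound 2 to compound 3 (beyond the scatter), so a change confined to the saturated chain is enough to move the read-out beyond the scatter. The advantage gained by the earlier exchange on the aromatic carbon does not persist with the lengthened chain, as a number 4.4 percentage points higher from compound 1 to compound 3 (within the scatter) shows, and that step lies within the scatter. Nothing at hand accounts for the loss seen on lengthening the chain.

On these data alone, a single lengthening gives two points on the chain and no trend, so it remains open whether a shorter chain or a still longer chain would hold the read-out, fall further or recover it. Also open, as far as these compounds go, is how far the read-out depends on the terminal group itself, which an amine or a carboxylic acid at the chain end would test, and whether the lengthened chain behaves the same way on the sulfonamide.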